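The compounds below may be only part of what the source reports. "The series", "measured", "known", "first", "only" and "open" are said of these compounds alone.

Measured so far in a functional assay on MCF7 cells (Homo sapiens) for antiproliferative activity, read by MTT assay, with a stated time of 72 h; a higher number here means a weaker inhibitor, a lower number a stronger inhibitor:
compound 1 `CCN(CC)CCNc1cc(C)c2cc(NC(=O)c3ccc(Cl)c(Cl)c3)ccc2n1` gives 1420 nM
compound 2 `CCc1ccccc1C(=O)Nc1ccc2nc(N3CCN(CC)CC3)cc(C)c2c1` gives 15800 nM
compound 3 `CCN1CCN(c2cc(C)c3cc(NC(=O)c4ccc(F)cc4)ccc3n2)CC1` gives 4030 nM

Compound 2 stands at the top of the three numbers: compound 3 comes nearest, and compound 1 lies furthest down. Compound 4 `CCN1CCN(c2cc(C)c3cc(NC(=O)c4ccc(Cl)c(Cl)c4)ccc3n2)CC1` is the next member to be run in this assay. The change from compound 2 to compound 4 is 3,4-dichlorophenyl in place of 2-ethylphenyl on a carbonyl carbon.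

Within the data shown here, one measured step bears on this change directly: a 3.9-fold lower number from compound 2 to compound 3 (0.59 log units; beyond the scatter), where another aryl group replaced 2-ethylphenyl on the same carbonyl carbon of the same core. Among the measured compounds shown here, compound 1 also carries 3,4-dichlorophenyl on its carbonyl, though on a different amine-bearing core, and its value of 1420 nM sits well under that of compound 2; no single-point step connects those two, so this is only a hint.

Taken together, a drop of roughly the size seen from compound 2 to compound 3, possibly somewhat larger, is expected for compound 4, which is estimated at 2500 nM (range 1000 nM to 6300 nM). That estimate corresponds to an expected step of a 6.3-fold lower number from compound 2 to compound 4 (0.80 log units; beyond the scatter).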

Compound 4, half-maximal inhibitory concentration: 1380 nM
Estimate against measurement, compound 4: 1.8-fold (0.26 log units) above, within the range that was stated.
By their numbers in this assay, from the lowest: compounds 4 and 1 (each within the scatter of the next); then compound 3; then compound 2.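

On the carbonyl carbon of the shared core in this assay, 3,4-dichlorophenyl in place of 2-ethylphenyl gives an 11-fold lower number from compound 2 to compound 4 (1.06 log units; beyond the scatter) and in place of 4-fluorophenyl gives a 2.9-fold lower number from compound 3 to compound 4 (0.47 log units; beyond the scatter), so this aryl position separates all three compounds of that core. With 3,4-dichlorophenyl held on the carbonyl, 4-ethylpiperazin-1-yl in place of (2-(diethylamino)ethyl)amino on an aromatic carbon leaves a 1.0-fold lower number from compound 1 to compound 4 (0.01 log units; within the scatter), so this amine exchange produces no readable difference in this pair. Nothing available accounts for these steps.

On these data alone, whether a single chlorine, as in 4-chlorophenyl, would hold the value of compound 4 remains open. Also open, as far as these compounds go, is whether the match between the two amine groups persists with other aryl groups on the carbonyl, or with a morpholine on the aromatic carbon.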